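From 3-nitrophenyl to 2-chlorophenyl: an expected small step

This account rests on a few compounds, and the source may have more. Where it says the series, first, only, none or still open, it means among the compounds named here.

Values measured in a functional assay on A549 cells (Homo sapiens) for antiproliferative activity, read by MTT assay (a lower number here means a stronger inhibitor, a higher number a weaker inhibitor), for three compounds with a shared core:
- compound 1 (`Cc1cc(C)c(/C=N/Nc2ncc3c(n2)n(C2CCCC2)c(=O)c(=O)n3C)c(C)c1`) gives 12000 nM
- compound 2 (`Cc1ccc(/C=N/Nc2ncc3c(n2)n(C2CCCC2)c(=O)c(=O)n3C)cc1C`) gives 30200 nM
- compound 3 (`Cn1c(=O)c(=O)n(C2CCCC2)c2nc(N/N=C/c3cccc([N+](=O)[O-])c3)ncc21`) gives 12300 nM

Compound 3 stands with the lower pair of numbers, as a 1.0-fold higher number from compound 1 to compound 3 (0.01 log units; within the scatter) and a 2.5-fold lower number from compound 2 to compound 3 (0.39 log units; beyond the scatter) show. The next compound to consider is compound 4 (`Cn1c(=O)c(=O)n(C2CCCC2)c2nc(N/N=C/c3ccccc3Cl)ncc21`). It has 2-chlorophenyl in place of 3-nitrophenyl on a carbon with a double bond to nitrogen.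

For the measured compounds named here, no measured compound carries a chlorine, so the evidence is indirect. All three measured steps do change the group at this same place, however. Two are modest, a 2.5-fold higher number from compound 1 to compound 2 (0.40 log units; beyond the scatter) and a 2.5-fold lower number from compound 2 to compound 3 (0.39 log units; beyond the scatter) as well, and the third is a 1.0-fold higher number from compound 1 to compound 3 (0.01 log units; within the scatter) in size. Swaps here have therefore moved the number only a little, and in both directions. In this assay the expectation for compound 4 is no step beyond the scatter, or at most a modest one, with a slightly higher number somewhat more likely than a lower one. The estimated change is a 1.3-fold higher number from compound 3 to compound 4 (0.11 log units; within the scatter) for this swap. The estimate for compound 4 is 16000 nM (expected range 8000 nM to 32000 nM).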

Compound 4, half-maximal inhibitory concentration: 9860 nM
Compound 4: the middle estimate sits 1.6-fold (0.21 log units) above what was measured; the range from low to high includes it.
By their numbers in this assay, from the lowest: compounds 4, 1 and 3 (each within the scatter of the next); then compound 2.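

In this assay, replacing 3-nitrophenyl with 2-chlorophenyl removes both hydrogen-bond acceptors of the leaving group and brings in a chlorine, yet the result is a 1.2-fold lower number from compound 3 to compound 4 (0.10 log units; within the scatter); for this pair, then, a large change in the atoms of the group leaves the number within the scatter. For the compounds shown here, the chlorine compound also shows a 1.2-fold lower number from compound 1 to compound 4 (0.09 log units; within the scatter), so three different groups at this place now give values that cannot be told apart, while a 3.1-fold lower number from compound 2 to compound 4 (0.49 log units; beyond the scatter) leaves the 3,4-dimethylphenyl of compound 2 as the one group whose number stands clearly apart from the others. Nothing available here explains why compound 2 differs from the other three or why such different groups give matching values.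

Going by these compounds, all four compounds keep a six-membered aromatic ring of carbon only at this place, so it remains open how the number would respond to a pyridine ring, or to a saturated chain in place of the ring. Going by these compounds alone, also open is what an amine or a carboxylic acid on the ring would do, since every step so far stays modest or smaller.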